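A few compounds are considered here, and "the series" means these few. Any claim that something is new, unique, unknown or untested is made for them only; others in the source may bear on it.

Compound 2 `COC1CCN(C(=O)N2CC(c3nc(-c4cccc(Cl)c4)no3)C2)CC1` is one of three compounds tested in an assay on HEK293 cells for negative allosteric modulation of metabotropic glutamate receptor 5 (Homo sapiens), read by FLIPR; a higher number here means a weaker inhibitor, a lower number a stronger inhibitor. In this assay compound 2 gives > 10000 nM, which is a limit of the assay and not a number. Compound 1 `O=C(C1CCCCC1)N1CC(c2nc(-c3cccc(F)c3)no2)C1` gives > 10000 nM in this assay, likewise a limit. Compound 3 `O=C(c1ccc(Cl)cc1)N1CC(c2nc(-c3cccc(F)c3)no2)C1` gives > 10000 nM in this assay, also a limit. All three values sit at the limit of > 10000 nM in this assay, at which 3 of the 3 values shown sit, so the step that the two limits leave unreadable from compound 1 to compound 3 cannot be read. Compound 4 `O=C(C1CCC1)N1CC(c2nc(-c3cccc(Cl)c3)no2)C1` differs from compound 2 by cyclobutyl in place of 4-methoxypiperidin-1-yl on a carbonyl carbon. For the measured compounds named here, no measured step bears on this change. The step of a number no higher from compound 2 to compound 4 (the limit leaves the size open) is expected to stay within the scatter, since all shown values sit at the limit of > 10000 nM in this assay, at which 3 of the 3 values shown sit. The estimate for compound 4 in this assay is 10000 nM, within 3000 nM to 30000 nM.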

Compound 4, half-maximal inhibitory concentration: 1500 nM
Compound 4: middle estimate off by 6.7-fold (0.82 log units), on the high side; the whole stated range lies above it.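

In this assay, the group on this carbonyl carbon decides whether a value can be read at all: cyclobutyl in place of 4-methoxypiperidin-1-yl gives an at least 6.6-fold lower number from compound 2 to compound 4 (0.82 log units; beyond the scatter). The step has only a lower bound, and compound 4 alone has a value that is not a limit: the limit of > 10000 nM in this assay, at which 3 of the 4 values shown sit.

The compounds shown leave open whether cyclopropyl or an isopropyl chain on this carbonyl carbon would match compound 4. They also do not separate the smaller ring from the loss of the methoxy group or the ring nitrogen.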